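Bromo for Fluoro: Expected Maximal Response of Compound 3

The compounds below may be only part of what the source reports. "The series", "measured", "known", "first", "only" and "open" are said of these compounds alone.

Compound 1 `Cc1ccc(Oc2cccc(COc3ccccc3CCC(=O)OCCCOP(=O)(O)OC[C@H](N)C(=O)O)c2)cc1` — 18.2%
Compound 2 `N[C@@H](COP(=O)(O)OCCCOC(=O)CCc1ccccc1OCc1cccc(Oc2ccc(F)cc2)c1)C(=O)O` — 18.7%

Among the measured compounds shown here, in an assay on cells for agonist activity at probable G-protein coupled receptor 34 (Mus musculus), with a stated time of 1 h (on this read-out lower numbers stand for smaller maximal responses and higher numbers for larger maximal responses), compound 2 stands at 18.7%, and the only other measured compound, compound 1, lies within the scatter of it, the step being a number 0.5 percentage points higher from compound 1 to compound 2 (within the scatter). Compound 3 `N[C@@H](COP(=O)(O)OCCCOC(=O)CCc1ccccc1OCc1cccc(Oc2ccc(Br)cc2)c1)C(=O)O` differs from compound 2 by bromo in place of fluoro on an aromatic carbon. For the measured compounds named here, the one measured step, a number 0.5 percentage points higher from compound 1 to compound 2 (within the scatter), also exchanged a single substituent on an aromatic carbon and stayed within the scatter, so for compound 3 no step beyond the scatter is expected: a number 0.3 percentage points higher from compound 2 to compound 3 (within the scatter). Compound 3 is therefore estimated at 19%, expected to fall between 9% and 32%.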

Compound 3, largest response reached (Emax), in percent of the reference or control that the assay uses: 17.7%
Estimate against measurement, compound 3: 1.3 percentage points above; measured number inside the range.
By their numbers in this assay, from the lowest: compounds 3, 1 and 2 (each within the scatter of the next).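

In this assay bromo in place of fluoro gives a number 1 percentage points lower from compound 2 to compound 3 (within the scatter) and bromo in place of methyl gives a number 0.5 percentage points lower from compound 1 to compound 3 (within the scatter) at the same aromatic carbon, para to a large group. Methyl, fluoro and bromo at this position therefore all lie within the scatter of one another, so the insensitivity seen with one exchange now holds across all three pairs of these substituents. No measurement shown here offers an explanation for this result. Going by these compounds, whether an amine, a carboxylic acid or a longer chain at this position would change the maximal response remains open. So does the outcome of placing bromo elsewhere on this ring.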